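This account rests on a few compounds, and the source may have more. Where it says the series, first, only, none or still open, it means among the compounds named here.

Three analogues share one core and differ only in the aryl group on the carbonyl carbon. Compound 1 `COc1ccc(-c2cnc(NC(=O)c3ccccc3O)n2C)cc1` carries a 2-hydroxyphenyl there, compound 2 `COc1ccc(-c2cnc(NC(=O)c3cccc(C#N)c3)n2C)cc1` a 3-cyanophenyl and compound 3 `COc1ccc(-c2cnc(NC(=O)c3ccc(F)cc3)n2C)cc1` a 4-fluorophenyl. In a toxicity assay on THP-1 cells (Homo sapiens) for inhibition (a lower number here means that less compound is tolerated, a higher number that more compound is tolerated), compound 1 gives > 100000 nM, which is a limit of the assay and not a number. In this assay compound 2 gives > 100000 nM, again a limit. In this assay compound 3 gives >= 50000 nM, also a limit. Compound 3 thus stands at the limit of >= 50000 nM in this assay, at which 1 of the 3 values shown sits, whereas the other two values sit at the limit of > 100000 nM in this assay, at which 2 of the 3 values shown sit. Because all three are limits, the step that the two limits leave unreadable from compound 1 to compound 3 cannot be read, nor can a step that the two limits leave unreadable from compound 2 to compound 3 or a step that the two limits leave unreadable from compound 1 to compound 2. The fourth member, compound 4 `COc1ccc(-c2cnc(NC(=O)c3ccccc3OC)n2C)cc1`, differs from compound 3 by 2-methoxyphenyl in place of 4-fluorophenyl on a carbonyl carbon. Within the data shown here, none of the measured steps is readable, so none gives a size for this change; the only information is that every value so far lies at a limit. For compound 4 the expected step is a step that the limit leaves unreadable from compound 3 to compound 4, with no direction claimed. Compound 4 is therefore expected to give 100000 nM in this assay, estimated between 50000 nM and 300000 nM, most likely again reported as a limit.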

Compound 4, half-maximal cytotoxic concentration: > 100000 nM
Compound 4: only a limit was reported; the forecaster's own chance of this, stated with the estimate: 80%; the middle value lies on the limit itself.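

In this assay compound 4 gives > 100000 nM, which is a limit of the assay and not a number. Its steps from compound 1, compound 2 and compound 3 cannot be read. The compounds shown leave open how much of any of these four analogues is tolerated, and whether the group on the carbonyl carbon changes that at all.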